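A few compounds are considered here, and "the series" means these few. Any claim that something is new, unique, unknown or untested is made for them only; others in the source may bear on it.

Compound 1 `COCCOC(=O)c1cc(N)c(Nc2ccc(C#N)cc2)cc1Oc1c(C)cc(/C=C/C#N)cc1C`: > 5
Compound 2 `Cc1cc(/C=C/C#N)cc(C)c1Oc1cc(Nc2ccc(C#N)cc2)c(N)cc1C(=O)NCCCO`: 3.22

Within the data shown here, in a physicochemical assay for lipophilicity, read by HPLC, measured as octanol-water partition, with a stated time of 24 h, at pH 7.4 (on this read-out higher numbers stand for higher lipophilicity and lower numbers for lower lipophilicity), compound 2 gives 3.22, the only plain number among the two measured compounds. For compound 1 this assay reports a limit rather than a number, > 5. The value of compound 1 is the limit of > 5 in this assay, at which 1 of the 2 values shown sits. Among the measured compounds shown here, the one measured step gives a number at least 1.78 log units lower from compound 1 to compound 2 (beyond the scatter), where a (3-hydroxypropyl)amino replaces a 2-methoxyethoxy on the carbonyl carbon.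

Compound 3 `CNC(=O)c1cc(N)c(Nc2ccc(C#N)cc2)cc1Oc1c(C)cc(/C=C/C#N)cc1C` has not been measured. Against compound 2 the difference is hydrogen in place of 2-hydroxyethyl on a saturated chain carbon bound to an amide-type nitrogen; cut one bond further out, this reads 3-hydroxypropyl to methyl. The step from compound 1 to compound 2 changed the same carbonyl substituent but in a different way, so it bears on the present change only loosely. The chain shortens and the hydroxyl leaves, so the expected step is small, a number 0.28 log units higher from compound 2 to compound 3 (within the scatter). Compound 3 is therefore estimated at 3.5, with a range from 2.9 to 4.1.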

Compound 3, partition coefficient: 2.65
Compound 3: middle estimate off by 0.85 log units, on the high side; measured number outside the range, below it.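

Two amides can now be compared directly. In this assay, going from (3-hydroxypropyl)carbamoyl to methylcarbamoyl gives a number 0.57 log units lower from compound 2 to compound 3 (beyond the scatter), so shortening the chain and removing the hydroxyl together do not raise the number at this position. The low reading does not need the 3-hydroxypropyl chain either: methylamino in place of 2-methoxyethoxy on the carbonyl carbon gives a number at least 2.35 log units lower from compound 1 to compound 3 (beyond the scatter). That step is only a bound, because compound 1 carries a limit and not a number: the limit of > 5 in this assay, at which 1 of the 3 values shown sits.

Chain length and the hydroxyl change together from compound 2 to compound 3, so the compounds shown cannot tell which of the two accounts for the step. A plain propyl group on the amide nitrogen would keep the chain without the hydroxyl, and a chain ending in an amine would test a different end group.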